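A few compounds are considered here, and "the series" means these few. Any claim that something is new, unique, unknown or untested is made for them only; others in the source may bear on it.

Compound 1 `CC(=O)/C=C/c1cc(C)c(Oc2ccc([N+](=O)[O-])c(Nc3ccc(C#N)cc3)n2)c(C)c1`: > 46700 nM
Compound 2 `Cc1cc(/C=C/C#N)cc(C)c1Oc1ccc([N+](=O)[O-])c(Nc2ccc(C#N)cc2)n1`: > 48600 nM

In an ADME assay on TZM cells (Homo sapiens) for cytotoxicity, read by XTT assay, with a stated time of 4 days (a lower number here means that less compound is tolerated, a higher number that more compound is tolerated), compound 1 gives > 46700 nM, which is a limit and not a number. From the compounds shown here alone, compound 2 also stands only at a limit, > 48600 nM, so its true value is unknown. Compound 3 `Cc1cc(/C=C/C#N)cc(C)c1Oc1ccc(N)c(Nc2ccc(C#N)cc2)n1` carries amino in place of nitro on an aromatic carbon. Among the measured compounds shown here, the one measured step, a step that the two limits leave unreadable from compound 1 to compound 2, concerns a different place and offers no size to carry over. In this assay a modest move towards less compound tolerated is expected, though another limit may well appear. The expected change is an at least 1.6-fold lower number from compound 2 to compound 3 (0.20 log units; that floor lies within the scatter). For compound 3 the estimated value is 30000 nM, with an expected range of 8000 nM to 80000 nM.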

Compound 3, half-maximal cytotoxic concentration: 9750 nM
For compound 3 the middle estimate is 3.1-fold (0.49 log units) above the measured one, and the stated range covers the measured number.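

Among the compounds shown here, replacing nitro with amino on this aromatic carbon, para to a large group, gives the only readable step here in this assay, with an at least 4.9-fold lower number from compound 2 to compound 3 (0.69 log units; beyond the scatter). So this position can change how much compound the cells tolerate, something the chain change could not show, since the step between the two earlier compounds cannot be read. The true gap may be larger, because compound 2 stands at a limit and not at a number: the limit of > 48600 nM in this assay, at which 1 of the 3 values shown sits.

From the compounds shown here alone, whether a methylamino group or a plain hydrogen on this carbon would lower the number in the same way remains open. So does whether the same swap would act alike on the acetyl chain of compound 1.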